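The compounds below may be only part of what the source reports. "The series", "measured", "known", "first", "only" and "open" are said of these compounds alone.

Measured so far:
Compound 1, `CN1CCN(c2ccc(Nc3ncc4nc(Nc5ccc(F)cc5)n(-c5cccc(NC(=O)CO)c5)c4n3)cc2)CC1`: 580 nM
Compound 2, `CN1CCN(c2ccc(Nc3ncc4nc(Nc5ccccc5)n([C@H]5CCN(S(C)(=O)=O)C5)c4n3)cc2)CC1`: "not determined" (no result reported)

For the measured compounds named here, in a functional assay on NCI-H1975 cells (Homo sapiens) for antiproliferative activity, read by MTT assay, with a stated time of 72 h (a higher number here means a weaker inhibitor, a lower number a stronger inhibitor), compound 1 gives 580 nM, the only number available, so it stands alone as the reference point. Compound 2 carries no reported result and offers no comparison. Compound 3, `CN1CCN(c2ccc(Nc3ncc4nc(Nc5ccc(F)cc5)n([C@H]5CCN(S(=O)(=O)C6CC6)C5)c4n3)cc2)CC1`, differs from compound 1 in one place: 1-(cyclopropylsulfonyl)pyrrolidin-3-yl in place of 3-(((hydroxymethyl)carbonyl)amino)phenyl on an aromatic nitrogen. Going by the values given here, no step between measured compounds is known, so the size of this change cannot be read from earlier pairs; a step of modest size in either direction seems as likely as none beyond the scatter. Compound 3 is expected to give about 450 nM, within 120 nM to 1700 nM. This corresponds to an expected step of a 1.3-fold lower number from compound 1 to compound 3 (0.11 log units; within the scatter).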

Compound 3, half-maximal inhibitory concentration: 580 nM
Compound 3: middle estimate off by 1.3-fold (0.11 log units), on the low side, within the range that was stated.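

On this aromatic nitrogen, in this assay, 1-(cyclopropylsulfonyl)pyrrolidin-3-yl in place of 3-(((hydroxymethyl)carbonyl)amino)phenyl gives no change at the digits printed from compound 1 to compound 3 (within the scatter). So an aromatic ring carrying 2 hydrogen-bond donors and a non-aromatic sulfonyl group carrying 0 can occupy this position with no readable difference in this cell assay. No supporting data explain this outcome.

On these data alone, whether the sulfonyl group or the pyrrolidine ring matters at all remains open. A plain cyclopentyl group or a free amine on the same nitrogen would help to test this.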